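A few compounds are considered here, and "the series" means these few. Any claim that something is new, unique, unknown or untested is made for them only; others in the source may bear on it.

Compound 1 `CCCCOC(=O)[C@@H](N)CCC(=O)NCCSC(=O)c1ccccc1`: 97000 nM
Compound 2 `CCCCOC(=O)[C@@H](N)CCC(=O)NCCSC(=O)C(C)(C)C`: 102000 nM
Compound 3 `CCCCOC(=O)[C@@H](N)CCC(=O)NCCSC(C)=O`: 563000 nM

In an ADME assay on HaCaT cells (Homo sapiens) for cytotoxicity, read by MTT assay, with a stated time of 48 h (on this read-out higher numbers stand for an effect only at larger amounts of compound and lower numbers for an effect already at smaller amounts), compound 1 sits at the low end of this small series, level with its tert-butyl counterpart, a 1.1-fold higher number from compound 1 to compound 2 (0.02 log units; within the scatter). The methyl member stands apart, with a 5.8-fold higher number from compound 1 to compound 3 (0.76 log units; beyond the scatter) and a 5.5-fold higher number from compound 2 to compound 3 (0.74 log units; beyond the scatter).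

Compound 4 `CCCOC(=O)[C@@H](N)CCC(=O)NCCSC(=O)c1ccccc1` carries a single change from compound 1: hydrogen in place of methyl on a saturated chain carbon, three bonds along the chain from an oxygen next to a carbonyl group, which reads butyl to propyl. Among the compounds with values here, no measured step touches this chain, as all three fall on a carbonyl carbon elsewhere in the molecule, so they offer only indirect guidance. Methyl in place of the larger groups gave modest steps towards higher numbers, yet tert-butyl in place of phenyl gave none, as a 1.1-fold higher number from compound 1 to compound 2 (0.02 log units; within the scatter) shows. Losing one carbon from the chain is a smaller change than either modest step, so only a slight shift is expected, within the scatter: a 1.2-fold higher number from compound 1 to compound 4 (0.09 log units; within the scatter) is the estimated step. For compound 4 the estimated value is 120000 nM, with an expected range of 60000 nM to 240000 nM.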

Compound 4, half-maximal effective concentration: 75000 nM
For compound 4 the middle estimate is 1.6-fold (0.20 log units) above the measured one; low and high end bracket the measured number.
By their numbers in this assay, from the lowest: compounds 4, 1 and 2 (each within the scatter of the next); then compound 3.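

Going from butyl to propyl is the first change shown away from the carbonyl carbon, and in this assay it gives a 1.3-fold lower number from compound 1 to compound 4 (0.11 log units; within the scatter), so the read-out does not separate the two chains. Unlike the methyl steps on the carbonyl carbon, which lay beyond the scatter, hydrogen in place of methyl at this position, three bonds along the chain from an oxygen next to a carbonyl group, produces no readable shift. No evidence is available that bears on this result.

From the compounds shown here alone, whether the same holds for a pentyl or longer chain, or for an ethyl or methyl chain, remains open, as does the effect of a carboxylic acid in place of the ester. Going by these compounds, it is also open whether propyl behaves the same way alongside tert-butyl or methyl on the carbonyl carbon.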